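The source may hold more compounds than are shown below. What is called first, only, known or untested is meant among the compounds shown, and "the series" means these compounds.

Of the compounds shown here, three sharing one core have been measured in a functional assay on SW1573 cells (Homo sapiens) for antiproliferative activity, read by sulforhodamine B assay, with a stated time of 48 h; a lower number here means a stronger inhibitor of growth, a higher number a weaker inhibitor of growth. Compound 1 (`CC(C)(C)[Si](C)(C)O[C@H]1CCCO[C@@H]1COCC(=O)OCc1ccccc1`) gives 17000 nM, and compound 3 (`C=CCOC[C@H]1OCCC[C@H]1O[Si](C)(C)C(C)(C)C`) gives 18000 nM, so these two lie within the scatter of each other. Compound 2 (`O=C(COC[C@H]1OCCC[C@@H]1O)OCc1ccccc1`) gives > 100000 nM, which is a limit of the assay and not a number. Within the data shown here, the only measured step, an at least 5.8-fold higher number from compound 1 to compound 2 (0.76 log units; beyond the scatter), lies beyond the scatter and goes with the loss of the silicon-bearing group, which compound 4 (`CC(C)(C)[Si](C)(C)O[C@@H]1CCCO[C@@H]1COCCCO`) keeps. That step therefore bears on compound 4 only indirectly.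

Compound 4 differs from compound 3 in one place: 2-hydroxyethyl in place of vinyl on a saturated chain carbon bound to an oxygen on a saturated carbon. Among the measured compounds shown here, no measured step makes this change. However, compound 3 carries a different chain end from compound 1, and compound 1 still gives 17000 nM, so little movement is expected in this assay. The expected step, a 1.2-fold higher number from compound 3 to compound 4 (0.09 log units; within the scatter), is estimated to stay within the scatter. Compound 4 is expected at 22000 nM, with an estimated range of 9000 nM to 60000 nM.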

Compound 4, concentration for 50% growth inhibition: > 100000 nM
Compound 4: a limit, no number; the forecaster's own chance of this, stated with the estimate: 15%; middle value at least 4.5-fold (0.65 log units) from the limit.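

In this assay, 2-hydroxyethyl in place of vinyl on a saturated chain carbon bound to an oxygen on a saturated carbon comes with an at least 5.5-fold higher number from compound 3 to compound 4 (0.74 log units; beyond the scatter). Among these compounds, until this result, the only step beyond the scatter went with the loss of the silicon-bearing group, whereas compound 4 keeps that group, so this change shows that the end of the chain at this position also matters. Keeping the silicon-bearing group is thus not enough on its own to hold growth inhibition within the range that this assay reads.

How large the step really is stays open, since only its lower bound can be read: the limit of > 100000 nM in this assay, at which 2 of the 4 values shown sit.

Also open, on these data alone, is whether a methyl ether, an amine or a carboxylic acid at the end of this chain would behave like vinyl or like 2-hydroxyethyl.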